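The compounds below may be only part of what the source reports. "The series", "measured", "known", "first", "only" and "open" are said of these compounds alone.

Compound 1 `CCCC[S+]([O-])c1sc2nc(-c3nccs3)cc(-c3ccc(CN)cc3)c2c1N` and compound 2 `CCCC[S+]([O-])c1sc2nc(-c3nccs3)cc(-c3ccc(C(=O)N(C)C)cc3)c2c1N` share one core and differ in a single group on an aromatic carbon. In an assay for inhibition of 15-hydroxyprostaglandin dehydrogenase [NAD(+)] (Homo sapiens), read by fluorescence, with a stated time of 15 min, in the presence of a further agent that is not named here (a lower number here means a stronger inhibitor, a higher number a weaker inhibitor), compound 1 gives 11.5 nM, and compound 2 gives 5.9 nM. Going by the values given here, of the two numbers measured so far, compound 1 stands highest, with compound 2 as its nearest neighbour; the step of a 1.9-fold lower number from compound 1 to compound 2 (0.29 log units; within the scatter) lies within the scatter, so the two compounds are not told apart by these measurements. Compound 3 `CCCC[S+]([O-])c1sc2nc(-c3nccs3)cc(-c3cnc(C)[nH]3)c2c1N` has not yet been measured. It differs from compound 1 in that (2-methyl-1H-imidazol-5-yl in place of 4-(aminomethyl)phenyl on an aromatic carbon). Among the compounds with values here, the only measured step, a 1.9-fold lower number from compound 1 to compound 2 (0.29 log units; within the scatter), exchanges one group for another on the 4-(aminomethyl)phenyl and leaves that ring in place; it does not replace the ring itself, so it bears only loosely on the present change. Within the data shown here, with no step of the same kind to draw on, the change from compound 1 to compound 3 is expected to stay roughly within the scatter, estimated as a 1.7-fold higher number from compound 1 to compound 3 (0.24 log units; within the scatter). The expected value of compound 3 in this assay is 20 nM, with a range from 5 nM to 80 nM.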

Compound 3, half-maximal inhibitory concentration: 2.3 nM
The estimate for compound 3 lay 8.7-fold (0.94 log units) above the measured number; measured number below the stated range.
By their numbers in this assay, from the lowest: compound 3; then compounds 2 and 1 (each within the scatter of the next).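

In this assay, exchanging the whole ring for another gives a 5.0-fold lower number from compound 1 to compound 3 (0.70 log units; beyond the scatter), so this position, opposite the ring nitrogen, accepts a five-membered aromatic ring with 2 hetero atoms in place of a six-membered aromatic ring of carbon only, and the number falls beyond the scatter. Going by these compounds alone, the only earlier change at this position, a 1.9-fold lower number from compound 1 to compound 2 (0.29 log units; within the scatter), altered a group on the ring and left the ring in place, so it could not show that replacing the ring itself separates two compounds. The 4-(aminomethyl)phenyl and 2-methyl-1H-imidazol-5-yl groups have the same counts of hydrogen-bond donors and acceptors and no net charge, so those counts do not follow the step, and no measurement at hand explains it.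

The compounds shown leave open what the methyl group on the imidazole contributes, which an unsubstituted imidazole or one carrying an ethyl group would test. They also leave open whether the imidazole is needed at all, or whether another five-membered ring, such as a pyrazole or a thiazole, would serve at this position.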